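A few compounds are considered here, and "the series" means these few. Any claim that something is new, unique, unknown or untested is made for them only; others in the source may bear on it.

Three compounds share one core and differ only in the aromatic group attached to a carbonyl carbon. Compound 1 `COC(=O)c1cc2cc(NCc3cc(NC(=O)c4cncc(C)c4)ccc3C)cnc2[nH]1` gives 510 nM in a functional assay on HepG2 cells (Homo sapiens) for antiproliferative activity, read by MTT assay, with a stated time of 72 h; on this read-out lower numbers stand for an effect already at smaller amounts and higher numbers for an effect only at larger amounts of compound. Compound 2 `COC(=O)c1cc2cc(NCc3cc(NC(=O)c4ccnc(C)c4)ccc3C)cnc2[nH]1` is reported in this assay only as a limit, > 1000 nM. Compound 3 `COC(=O)c1cc2cc(NCc3cc(NC(=O)c4cncc(C(F)(F)F)c4)ccc3C)cnc2[nH]1` gives 963 nM in this assay. Among the two plain numbers, compound 3 holds the higher one, and the step of a 1.9-fold higher number from compound 1 to compound 3 (0.28 log units; within the scatter) stays within the usual scatter; the step of an at least 1.9-fold higher number from compound 1 to compound 2 (0.29 log units; that floor lies within the scatter) likewise does not leave it. The floor set by the limit of compound 2 the limit of > 1000 nM in this assay, at which 1 of the 3 values shown sits, is also what the step of an at least 1.0-fold lower number from compound 2 to compound 3 (0.01 log units; that floor lies within the scatter) rests on.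

Compound 4 `COC(=O)c1cc2cc(NCc3cc(NC(=O)c4ccc5[nH]ccc5c4)ccc3C)cnc2[nH]1` has not been measured. It differs from compound 3 in one place: 1H-indol-5-yl in place of 5-(trifluoromethyl)pyridin-3-yl on a carbonyl carbon. Within the data shown here, the only measured steps on this same carbonyl carbon, the exchanges of the aromatic groups among compounds 1, 2 and 3, all stayed within the scatter, so no step beyond the scatter is expected in this assay, in either direction. Compound 4 is therefore estimated at 750 nM, between 300 nM and 2000 nM, which means an expected step of a 1.3-fold lower number from compound 3 to compound 4 (0.11 log units; within the scatter).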

Compound 4, half-maximal effective concentration: > 1000 nM
Compound 4 was reported as a limit; the forecaster's own chance of this, stated with the estimate: 25%; middle value at least 1.3-fold (0.12 log units) from the limit.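

With 1H-indol-5-yl on this carbonyl carbon, a group with a five-membered and a six-membered aromatic ring takes the place of the single ring of 5-(trifluoromethyl)pyridin-3-yl, and a hydrogen-bond donor replaces a hydrogen-bond acceptor. Even this larger change of ring type yields only floors that stay within the scatter in this assay: the readable steps are an at least 1.0-fold higher number from compound 3 to compound 4 (0.01 log units; that floor lies within the scatter) and an at least 1.9-fold higher number from compound 1 to compound 4 (0.29 log units; that floor lies within the scatter) and neither shows a real difference. Compound 4 is reported only as a limit, the same one as compound 2: the limit of > 1000 nM in this assay, at which 2 of the 4 values shown sit.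

From the compounds shown here alone, the step between compound 2 and compound 4 cannot be read, and the actual value of compound 4 stays open. Also open, going by these compounds, is how a non-aromatic group on this carbonyl carbon, such as a cyclohexyl ring or a chain ending in an amine, would behave.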